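The source may hold more compounds than are shown below. What is called first, only, known or untested is meant among the compounds shown, and "the series" means these compounds.

Three compounds have been measured in an ADME assay on BV-2 cells (Mus musculus) for cytotoxicity, with a stated time of 24 h, tested at 50 uM; on this read-out lower numbers stand for a stronger effect and higher numbers for a weaker effect at the one concentration tested:

Compound 1 `COc1ccccc1S(=O)(=O)/C=C/c1ccccn1` gives 100%.
Compound 2 `COc1ccccc1S(=O)(=O)/C=C/c1ncccc1F` gives 99.2%.
Compound 3 `COc1ccc(S(=O)(=O)/C=C/c2ccccn2)cc1` gives 100%.

Compound 2 differs from compound 1 by one change, (fluoro in place of hydrogen on an aromatic carbon), and that change brought a number 0.8 percentage points lower from compound 1 to compound 2 (within the scatter), so the two readings are practically the same. Compound 3 is built from the same atoms as compound 1, joined differently; the difference between the two cores is not broken down here. Its value stands level with that of compound 1 at the digits given.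

Compound 4 `COc1ccc(S(=O)(=O)/C=C/c2ncccc2F)cc1` has not yet been measured. It is compound 3 carrying the same change, (fluoro in place of hydrogen on an aromatic carbon), at the same kind of place. Because the earlier step was a number 0.8 percentage points lower from compound 1 to compound 2 (within the scatter), the step from compound 3 to compound 4 in this assay is expected to be about a number 1 percentage points lower from compound 3 to compound 4 (within the scatter), within the scatter. Compound 4 is therefore estimated at 99%, between 92% and 100%.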

Compound 4, a percentage reported as activity, at one concentration (the size of the read-out at that concentration, not a potency): 86.6%
Beside the measured number, compound 4's estimate is 12.4 percentage points above it; measured number below the stated range.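

On the core of compound 3, fluoro in place of hydrogen on an aromatic carbon gave a number 13.4 percentage points lower from compound 3 to compound 4 (beyond the scatter) in this assay, a step larger than the usual scatter of a single reading. This does not show that the change behaves differently on the two cores, since the gap between its two steps is not large enough to separate them:

the same change on two cores in this assay, a number 0.8 percentage points lower (within the scatter) from compound 1 to compound 2 and a number 13.4 percentage points lower (beyond the scatter) from compound 3 to compound 4, 12.6 percentage points apart, within the scatter of two such steps

Nor does it prove that the change carries over unchanged, as each core offers only a single pair of compounds.

The compounds shown leave open how a chlorine atom, a methyl group or an amine would read in place of the fluoro. They also leave open whether a third core would give a step like either of these two.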